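The source may hold more compounds than are shown below. What is called first, only, known or untested is meant among the compounds shown, and "the series" means these compounds.

Measured so far in a functional assay on MDA-MB-231 cells (Homo sapiens) for cytotoxicity, read by MTT assay, with a stated time of 72 h; a lower number here means a stronger inhibitor, a higher number a weaker inhibitor:
- compound 1 `CCCCCCNc1nc(SCc2ccc(C(F)(F)F)cc2)nc2ccccc12` gives 20200 nM
- compound 2 `FC(F)(F)c1ccc(CSc2nc(Nc3ccccc3)c3ccccc3n2)cc1` gives 18400 nM
- compound 3 `CCOc1ccccc1Nc1nc(SCc2ccc(C(F)(F)F)cc2)nc2ccccc12` gives only a limit, > 50000 nM

Compound 3 therefore stands above the other two measured compounds, but only as a limit of the assay, not as a number; see (the limit of > 50000 nM in this assay, at which 1 of the 3 values shown sits). The two steps leading into it both point the same way: an at least 2.4-fold higher number from compound 1 to compound 3 (0.39 log units; beyond the scatter) and an at least 2.7-fold higher number from compound 2 to compound 3 (0.43 log units; beyond the scatter). Within the scatter sits a 1.1-fold lower number from compound 1 to compound 2 (0.04 log units; within the scatter), so the swap of hexyl for phenyl on the ring nitrogen changed little, and the ethoxy on the aryl carbon is what pushed compound 3 past the limit.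

Compound 4 `Cc1ccccc1Nc1nc(SCc2ccc(C(F)(F)F)cc2)nc2ccccc12` is the next step: methyl in place of ethoxy on an aromatic carbon. The group entering counts one heavy atom where the group leaving counted three, and it carries no hydrogen-bond acceptor. Going by the values given here, the relevant measured step is the one from compound 2 to compound 3, which was at least modest and upward; compound 4 sits between compound 2 and compound 3 in substitution at that carbon, so a downward step back toward compound 2 is expected, though probably not all the way. The step from compound 3 to compound 4 in this assay is estimated as an at least 1.5-fold lower number from compound 3 to compound 4 (0.19 log units; that floor lies within the scatter). Compound 4 is expected at 32000 nM, with a range of 13000 nM to 80000 nM.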

Compound 4, half-maximal inhibitory concentration: 27100 nM
Compound 4: the middle estimate sits 1.2-fold (0.07 log units) above what was measured, within the range that was stated.
By their numbers in this assay, from the lowest: compounds 2, 1 and 4 (each within the scatter of the next). At a limit, above all of these: compound 3.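

Methyl on this aromatic carbon, ortho to a large group, does not separate compound 4 from its neighbours in this assay: the comparison with the unsubstituted phenyl gives a 1.5-fold higher number from compound 2 to compound 4 (0.17 log units; within the scatter), and the comparison with the hexyl amine gives a 1.3-fold higher number from compound 1 to compound 4 (0.13 log units; within the scatter). Of the two groups shown at this carbon, only ethoxy goes with a step beyond the scatter from compound 2, yet the direct change of ethoxy to methyl reads as an at least 1.8-fold lower number from compound 3 to compound 4 (0.26 log units; that floor lies within the scatter), so only a floor is known for it and that floor does not by itself separate the two groups. The value of compound 3 remains a limit and not a number: the limit of > 50000 nM in this assay, at which 1 of the 4 values shown sits.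

The compounds shown leave open whether the oxygen or the length of the ethoxy group goes with the loss of activity, a question that methoxy or propyl at the same carbon would address. Also open, on these data alone, is whether any other group at this carbon, such as fluorine or hydroxyl, or any other group on the nitrogen, such as cyclohexyl or benzyl, would give a number beyond the scatter from compound 1.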